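Benzyl for propyl carbamate on a selenocyanate core

The compounds below may be only part of what the source reports. "The series", "measured", "known", "first", "only" and "open" are said of these compounds alone.

Compound 1 `CCCOC(=O)Nc1ccc([Se]C#N)cc1` is one of two measured members of this series. In a functional assay on MCF7 cells (Homo sapiens) for cytotoxicity, read by MTT assay, with a stated time of 72 h (on this read-out lower numbers stand for stronger inhibition of growth and higher numbers for weaker inhibition of growth), compound 1 gives 34400 nM, the lowest of the two numbers shown, and compound 2 `O=C(Nc1ccc([Se][Se]c2ccc(NC(=O)OCc3ccccc3)cc2)cc1)OCc1ccccc1` gives 38600 nM, a figure within the scatter of that of compound 1. Compound 3 `N#C[Se]c1ccc(NC(=O)OCc2ccccc2)cc1` differs from compound 1 by phenyl in place of ethyl on a saturated chain carbon bound to an oxygen next to a carbonyl group. For the measured compounds named here, no measured pair isolates this change, so the step is expected to be small, without a fixed direction, and not beyond the scatter. Compound 3 is therefore estimated at 30000 nM, with a range from 12000 nM to 75000 nM, which means an expected step of a 1.1-fold lower number from compound 1 to compound 3 (0.06 log units; within the scatter).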

Compound 3, concentration for total growth inhibition: 38800 nM
Beside the measured number, compound 3's estimate is 1.3-fold (0.11 log units) below it, within the range that was stated.
By their numbers in this assay, from the lowest: compounds 1, 2 and 3 (each within the scatter of the next).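

Phenyl in place of ethyl on a saturated chain carbon bound to an oxygen next to a carbonyl group gives a 1.1-fold higher number from compound 1 to compound 3 (0.05 log units; within the scatter) in this assay. For the compounds shown here, this is the first measured step at this position, and it shows that exchanging the open ethyl for an aromatic ring leaves the number within the scatter. No measured data bear on why the number holds.

Still open, going by these compounds, is whether a longer chain, an amine or a carboxylic acid at this position would move the number beyond the scatter.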